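The compounds below may be only part of what the source reports. "The series", "measured", "known", "first", "only" and "open" are said of these compounds alone.

Measured compounds in a functional assay on MCF7 cells (Homo sapiens) for cytotoxicity, read by MTT assay, with a stated time of 72 h, tested at 10 uM; on this read-out higher numbers stand for more inhibition of growth at the one concentration tested and lower numbers for less inhibition of growth:
compound 1 `N/C(=N\NC(=S)N1CCOCC1)c1ccccn1` gives 66.7%
compound 2 `N/C(=N\NC(=S)N1CCN(c2ccccn2)CC1)c1ccc(F)cn1` gives 35.8%
compound 3 `Cc1ccnc(/C(N)=N/NC(=S)N2CCOCC2)c1` gives 6.86%

Compound 3 stands lowest of the three numbers in this assay; compound 2 lies nearer to it and compound 1 furthest away, both gaps beyond the scatter. For the measured compounds named here, the only single-change step among the measured compounds runs a number 59.8 percentage points lower from compound 1 to compound 3 (beyond the scatter), and it concerns a methyl group on an aromatic carbon, not the ring on the thiocarbonyl carbon.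

Compound 4 `Cc1ccnc(/C(N)=N/NC(=S)N2CCSCC2)c1` differs from compound 3 in one place: thiomorpholin-4-yl in place of morpholin-4-yl on a thiocarbonyl carbon. Going by the values given here, no measured pair shows what exchanging one ring with a single oxygen for one with a single sulfur does in this assay, so the step from compound 1 to compound 3 gives no guide here, and the value of compound 2 comes from a different ring altogether. With nothing to build on, no step beyond the scatter is expected; compound 4 is estimated at 12%, within -8% to 38%, an expected step of a number 5.1 percentage points higher from compound 3 to compound 4 (within the scatter).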

Compound 4, percent growth inhibition at one concentration: 62.5%
The estimate for compound 4 lay 50.5 percentage points below the measured number; the measured number lies above the stated range.
By their numbers in this assay, from the lowest: compound 3; then compound 2; then compounds 4 and 1 (each within the scatter of the next).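

In this assay the exchange of morpholin-4-yl for thiomorpholin-4-yl on a thiocarbonyl carbon gives a number 55.6 percentage points higher from compound 3 to compound 4 (beyond the scatter) and so shows that this position can move the number a long way. The earlier single-change step concerned only a methyl on an aromatic carbon, whereas here the two rings have the same count of heavy atoms, hydrogen-bond donors and hydrogen-bond acceptors, and sulfur in place of oxygen is the only difference. No measurement at hand explains why this single exchange has so large an effect.

As far as these compounds go, it remains open whether the same exchange would give a similar step on the core of compound 1, which has no methyl. Also open, from the compounds shown here alone, is how piperidin-1-yl, with carbon in place of that ring oxygen or sulfur, or an open-chain dimethylamino group would read on the same carbon.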